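Hedgehog inhibitor series: pyrazole for pyridine on the core

The source may hold more compounds than are shown below. What is called first, only, known or untested is meant among the compounds shown, and "the series" means these compounds.

compound 1 `Cc1cnc(Nc2ccc(C(=O)Nc3c(C)cccc3C)cc2)nc1-c1ccc(OC(F)(F)F)c(F)c1` — 159 nM
compound 2 `Cc1cnc(Nc2ccc(C(=O)Nc3c(C)cccc3C)cc2)nc1-c1ccncc1` — 0.54 nM

In an assay on NIH3T3 cells for inhibition of Sonic hedgehog protein (Mus musculus), read by a luciferase reporter, with a stated time of 48 h (a lower number here means a stronger inhibitor, a higher number a weaker inhibitor), compound 2 gives the lowest of the two numbers; the nearest is compound 1, and the step of a 290-fold lower number from compound 1 to compound 2 (2.47 log units; beyond the scatter) is large. Compound 3 `Cc1cnc(Nc2ccc(C(=O)Nc3c(C)cccc3C)cc2)nc1-c1cnn(C)c1` carries the change (1-methyl-1H-pyrazol-4-yl in place of pyridin-4-yl on an aromatic carbon), on an aromatic carbon of the shared core, next to the ring nitrogen and ortho to a methyl group. For the measured compounds named here, no measured step swaps one small aromatic ring for another at this place; the only bearing step, from compound 1 to compound 2, shows that this position moves the number strongly. A modest step of a 3.7-fold higher number from compound 2 to compound 3 (0.57 log units; beyond the scatter) toward a higher number is therefore expected, with wide uncertainty. Compound 3 is estimated at 2 nM, between 0.5 nM and 12 nM.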

Compound 3, half-maximal inhibitory concentration: 10.6 nM
The estimate for compound 3 lay 5.3-fold (0.72 log units) below the measured number; the measured number falls inside the stated range.
By their numbers in this assay, from the lowest: compound 2; then compound 3; then compound 1.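

In this assay, swapping one small aromatic ring for another at this place is not neutral: 1-methyl-1H-pyrazol-4-yl in place of pyridin-4-yl gives a 20-fold higher number from compound 2 to compound 3 (1.29 log units; beyond the scatter) despite the equal heavy-atom count. Replacing 3-fluoro-4-(trifluoromethoxy)phenyl with the same pyrazole still gives a 15-fold lower number from compound 1 to compound 3 (1.18 log units; beyond the scatter) and so places both smaller rings on the low side of the phenyl. No evidence at hand bears on the cause of these gaps.

Open, as far as these compounds go, is how the unmethylated pyrazole would compare with compound 3 at this place. Also open, from the compounds shown here alone, is how a non-aromatic group such as morpholine or a primary amine would read here.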